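This account rests on a few compounds, and the source may have more. Where it says the series, first, only, none or still open, it means among the compounds named here.

Compound 1 is `CCOC(=O)c1ccc(NC(=O)CSc2snnc2-c2ccccc2)c(Br)c1`. In an ADME assay on MT4 cells (Homo sapiens) for cytotoxicity (a higher number here means that more compound is tolerated, a lower number that less compound is tolerated), compound 1 gives >= 232000 nM, which is a limit of the assay and not a number. Compound 2 is `CCOC(=O)c1ccc(NC(=O)CSc2snnc2-c2ccc(Cl)cc2Cl)c(Br)c1`; in this assay compound 2 gives > 228000 nM, again a limit. Compound 3 is `COc1ccc(-c2nnsc2SCC(=O)Nc2ccccc2Br)cc1`, and in this assay compound 3 gives > 286000 nM, also a limit. Since every value is a limit, compound 1 cannot be placed in order among the three. Going by the values given here, the only single-point step, a step that the two limits leave unreadable from compound 1 to compound 2, carries 2,4-dichlorophenyl in place of phenyl on an aromatic carbon and is unreadable in size. Compound 4 is `COC(=O)c1ccc(NC(=O)CSc2snnc2-c2ccccc2)c(Br)c1`; it differs from compound 1 by hydrogen in place of methyl on a saturated chain carbon bound to an oxygen next to a carbonyl group, ethoxycarbonyl to methoxycarbonyl. Among the compounds with values here, no measured step touches this change; the evidence (the limit of >= 232000 nM in this assay, at which 1 of the 3 values shown sits), the limit of > 228000 nM in this assay, at which 1 of the 3 values shown sits, and the limit of > 286000 nM in this assay, at which 1 of the 3 values shown sits, shows only that each compound so far tolerated the highest concentration tested. Compound 4 is therefore expected to show a step that the limit leaves unreadable from compound 1 to compound 4, no step beyond the scatter. The estimate for compound 4 is 250000 nM, between 100000 nM and 600000 nM.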

Compound 4, half-maximal cytotoxic concentration: > 269000 nM
Compound 4 gave a limit, no number; the forecaster's own chance of this, stated with the estimate: 85%; middle value at least 1.0-fold (0.03 log units) from the limit.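

Compound 1 and compound 4 both stand as limits of the assay and not as numbers, so no step can be read between them. The compounds shown leave open whether ethoxycarbonyl to methoxycarbonyl, or any other change among them, shifts the concentration tolerated in this assay.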